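A few compounds are considered here, and "the series" means these few. Any claim that something is new, unique, unknown or untested is made for them only; others in the source may bear on it.

Compound 1 `Cc1ccc(N2C(=O)CSC2c2sc(Cc3ccc(Cl)cc3)nc2C)cc1` was tested in a functional assay on the whole organism (strain Wistar albino) for inhibition, with Rattus norvegicus as the target, read by paw edema, with stated times of 1 h and 2 h, at a dose of 40 mg/kg by the oral route (a lower number here means less inhibition, a higher number more inhibition at the dose given (going by the name of the read-out)), where compound 1 gives 61.4%. Compound 2 `COc1ccc(N2C(=O)CSC2c2sc(Cc3ccc(Cl)cc3)nc2C)cc1` differs from it by methoxy in place of methyl on an aromatic carbon; in this assay compound 2 gives 28.6%, a step of a number 32.8 percentage points lower from compound 1 to compound 2 (beyond the scatter). Compound 3 `Cc1ccc(N2C(=O)CSC2c2sc(-c3ccc(Cl)cc3)nc2C)cc1` differs from compound 1 by 4-chlorophenyl in place of 4-chlorobenzyl on an aromatic carbon, and in this assay compound 3 gives 37.6%, a step of a number 23.8 percentage points lower from compound 1 to compound 3 (beyond the scatter). Compound 4 `COc1ccc(N2C(=O)CSC2c2sc(-c3ccc(Cl)cc3)nc2C)cc1` has not yet been measured. It differs from compound 3 by methoxy in place of methyl on an aromatic carbon, the same change as that from compound 1 to compound 2, which appears twice among these compounds; the two cores differ by 4-chlorophenyl in place of 4-chlorobenzyl on an aromatic carbon. Because the same change earlier gave a number 32.8 percentage points lower from compound 1 to compound 2 (beyond the scatter), a similar downward step, a number 22.6 percentage points lower from compound 3 to compound 4 (beyond the scatter), is expected, tempered by the lower start of compound 3 at 37.6%. Compound 4 is therefore estimated at 15%, between 3% and 32%.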

Compound 4, a percentage reported as inhibition, in the whole organism at one dose (the size of the read-out at that dose, not a potency): 80.7%
For compound 4 the middle estimate is 65.7 percentage points below the measured one; the measured number lies above the stated range.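

Methoxy in place of methyl gives a number 43.1 percentage points higher from compound 3 to compound 4 (beyond the scatter) in this assay, so this change does not carry over from one core to the other, and its direction even reverses: the same change on two cores in this assay, a number 32.8 percentage points lower (beyond the scatter) from compound 1 to compound 2 and a number 43.1 percentage points higher (beyond the scatter) from compound 3 to compound 4, 75.9 percentage points apart, beyond the scatter of two such steps

The other change behaves the same way, with 4-chlorophenyl in place of 4-chlorobenzyl giving a number 52.1 percentage points higher from compound 2 to compound 4 (beyond the scatter): the same change on two cores in this assay, a number 23.8 percentage points lower (beyond the scatter) from compound 1 to compound 3 and a number 52.1 percentage points higher (beyond the scatter) from compound 2 to compound 4, 75.9 percentage points apart, beyond the scatter of two such steps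

For the compounds shown here, each change is seen on only two cores, so the result shows that the two changes do not act independently in these four compounds, but it does not explain why or predict the outcome on a further core.

As far as these compounds go, it remains open whether a hydroxy group or a chlorine in place of the methoxy would follow compound 2 or compound 4, and whether a longer chain in place of the 4-chlorobenzyl would keep the pattern.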